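Lengthening a polyether chain on a hindered phenol ester

The compounds below may be only part of what the source reports. "The series", "measured", "known", "first", "only" and "open" are said of these compounds alone.

Compound 1 `COCCOCCOCCOCCOCCOCCOCCOCCOCCOCCOC(=O)Oc1c(C(C)C)cccc1C(C)C` and compound 2 `COCCOCCOCCOCCOCCOCCOC(=O)Oc1c(C(C)C)cccc1C(C)C` share one core, and differ only in the length of the polyether chain. In an ADME assay on A549 cells (Homo sapiens) for cytotoxicity, read by MTT assay, with a stated time of 24 h (on this read-out lower numbers stand for an effect already at smaller amounts and higher numbers for an effect only at larger amounts of compound), compound 2 gives 730000 nM and compound 1 gives 400000 nM. The step of a 1.8-fold lower number from compound 2 to compound 1 (0.26 log units; within the scatter) comes from a group of 12 heavy atoms (8 carbon, 4 oxygen; no ring) in place of a hydrogen atom, on a saturated chain carbon bound to an oxygen on a saturated carbon. Compound 3 `COCCOCCOCCOCCOCCOCCOCC(=O)Oc1c(C(C)C)cccc1C(C)C` rests on a core that is not the same as that of compound 2; the difference between the two cores is not broken down here. In this assay compound 3 gives 520000 nM, which is close to the numbers of compound 1 and compound 2. Compound 4 `COCCOCCOCCOCCOCCOCCOCCOCCOCCOCCOCC(=O)Oc1c(C(C)C)cccc1C(C)C` is built from compound 3 by the same change, (a group of 12 heavy atoms (8 carbon, 4 oxygen; no ring) in place of a hydrogen atom, on a saturated chain carbon bound to an oxygen on a saturated carbon), at the same place. For compound 4 the expected step is a 1.5-fold lower number from compound 3 to compound 4 (0.17 log units; within the scatter). That expectation rests on the measured step of a 1.8-fold lower number from compound 2 to compound 1 (0.26 log units; within the scatter), which stayed small. It also rests on the starting point of compound 3 at 520000 nM. On this basis compound 4 is expected to give about 350000 nM in this assay, with a likely range from 200000 nM to 650000 nM.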

Compound 4, half-maximal effective concentration: 600000 nM
Estimate against measurement, compound 4: 1.7-fold (0.23 log units) below; low and high end bracket the measured number.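

In this assay, lengthening the polyether chain on the core of compound 3 gives a 1.2-fold higher number from compound 3 to compound 4 (0.06 log units; within the scatter). Set beside the same change on the other core, this step differs from the earlier one by no more than repeated measurements would: the same change on two cores in this assay, a 1.8-fold lower number (0.26 log units; within the scatter) from compound 2 to compound 1 and a 1.2-fold higher number (0.06 log units; within the scatter) from compound 3 to compound 4, 2.1-fold (0.32 log units) apart, within the scatter of two such steps. Among these compounds, the change therefore behaves alike on these two cores in one limited sense, that it leaves the number within the scatter on both, but with only one pair per core this does not show that the change has any real effect on either core, or that the same would hold on a third core.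

The compounds shown leave open whether a still longer chain or a much shorter one would move the number beyond the scatter. They also leave open what an amine or a carboxylic acid in place of the polyether chain would give.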